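A few compounds are considered here, and "the series" means these few. Any claim that something is new, unique, unknown or untested is made for them only; others in the source may bear on it.

Measured compounds:
compound 1, `CCO/C(O)=C1\C(C)=NC(C)=C(C(=O)OCCCN2C(=O)c3ccccc3S2(=O)=O)C1c1cccc(Cl)c1Cl`, 0.2 h
compound 2, `CCO/C(O)=C1\C(C)=NC(C)=C(C(=O)OCCCN2C(=O)c3ccccc3S2(=O)=O)C1c1ccccc1C(F)(F)F`, 0.155 h

Both were read in a functional assay on aorta with Voltage-dependent L-type calcium channel subunit alpha-1C (Oryctolagus cuniculus) as the target; on this read-out lower numbers stand for a shorter-lived compound and higher numbers for a longer-lived compound. Among the measured compounds shown here, compound 2 holds the lower of the two numbers, with compound 1 as its only neighbour; the step of a 1.3-fold lower number from compound 1 to compound 2 (0.11 log units; within the scatter) lies within the scatter, so the two compounds are not separated on this read-out.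

Compound 3, `COCCO/C(O)=C1\C(C)=NC(C)=C(C(=O)OCCCN2C(=O)c3ccccc3S2(=O)=O)C1c1ccccc1C(F)(F)F`, is the next member and has not been measured. It differs from compound 2 by methoxy in place of hydrogen on a saturated chain carbon, two bonds along the chain from an oxygen on an unsaturated carbon; read one bond further out, ethoxy becomes 2-methoxyethoxy. For the measured compounds named here, no measured step touches this chain: the only known step, a 1.3-fold lower number from compound 1 to compound 2 (0.11 log units; within the scatter), concerns the aryl group on the saturated ring carbon and is itself within the scatter. There is therefore nothing in the series that points to a change in either direction, and the step of a 1.0-fold higher number from compound 2 to compound 3 (0.01 log units; within the scatter) is expected to stay within the scatter. The expected value for compound 3 is 0.16 h, in the range 0.08 h to 0.35 h.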

Compound 3, half-life: 0.0717 h
Compound 3: the middle estimate sits 2.2-fold (0.35 log units) above what was measured; the measured number lies below the stated range.
By their numbers in this assay, from the lowest: compound 3; then compounds 2 and 1 (each within the scatter of the next).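

In this assay, among the compounds shown here, the chain carrying the ethoxy group is the first place where a single change separates two compounds: ethoxy to 2-methoxyethoxy gives a step beyond the scatter (a 2.2-fold lower number from compound 2 to compound 3 (0.33 log units; beyond the scatter)), though only a modest one. For the compounds shown here, the one earlier step, on the aryl group (a 1.3-fold lower number from compound 1 to compound 2 (0.11 log units; within the scatter)), did not separate its pair, so this chain is so far the only position with a readable effect on half-life, and that rests on a single pair carrying the 2-(trifluoromethyl)phenyl group. Nothing available accounts for the lower number of compound 3.

Going by these compounds, whether the same chain change gives a similar step with the 2,3-dichlorophenyl group of compound 1 remains open. Also open, on these data alone, is whether the step follows the methoxy oxygen or the added length, which a plain butoxy chain or a 2-hydroxyethoxy or 2-aminoethoxy chain could help to separate.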